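Moving the double bond one carbon outward on the chain

The compounds below may be only part of what the source reports. "The series", "measured", "known", "first", "only" and "open" are said of these compounds alone.

Compound 1 `CCCCCN(C1=NCCN1)c1c(Br)cccc1Br`, compound 2 `C=C(C)CN(C1=NCCN1)c1c(Br)cccc1Br` and compound 3 `CC(C)=CCN(C1=NCCN1)c1c(Br)cccc1Br` share one core and differ only in the chain on the nitrogen bound to the aromatic ring. In a physicochemical assay for acid dissociation, compound 1 gives 11, compound 2 gives 10.7 and compound 3 gives 10.8. Compound 1 is the reference point here: the nearest of the other two numbers is that of compound 3, a number 0.20 log units lower from compound 1 to compound 3 (within the scatter), and the furthest that of compound 2, a number 0.30 log units lower from compound 1 to compound 2 (within the scatter), so the three numbers cannot be told apart.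

Compound 4 `C=C(C)CCN(C1=NCCN1)c1c(Br)cccc1Br` has not been measured in this assay. Its change from compound 1 reads (1-methylethenyl in place of propyl on a saturated chain carbon, two bonds along the chain from a nitrogen on an aromatic ring). The two steps that bear on it are those from compound 1 to its two neighbours, a number 0.30 log units lower from compound 1 to compound 2 (within the scatter) and a number 0.20 log units lower from compound 1 to compound 3 (within the scatter), both within the scatter; compound 4 carries the same unsaturation as compound 2, only one bond further from the nitrogen. No step beyond the scatter is therefore expected in this assay, with at most a slight drift downward as for compound 2 and compound 3. For compound 4 the estimated step is a number 0.15 log units lower from compound 1 to compound 4 (within the scatter). Compound 4 is expected to give 10.85, within 10.5 to 11.2.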

Compound 4, acid dissociation constant: 10.9
Compound 4: the middle estimate sits 0.05 log units below what was measured, and the stated range covers the measured number.
By their numbers in this assay, from the lowest: compounds 2, 3, 4 and 1 (each within the scatter of the next).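

In this assay, placing the 1-methylethenyl group on the saturated chain carbon two bonds along the chain from the nitrogen on the aromatic ring, in place of propyl, gives a step within the scatter (a number 0.10 log units lower from compound 1 to compound 4 (within the scatter)). Compound 4 also cannot be told apart from the two earlier unsaturated compounds (a number 0.10 log units higher from compound 3 to compound 4 (within the scatter); a number 0.20 log units higher from compound 2 to compound 4 (within the scatter)). So among these four compounds, neither the double bond nor the three arrangements of it seen here separates the numbers, and no measurement on hand accounts for this.

Every chain shown is made of carbon and hydrogen alone, so it remains open whether an amine or a carboxylic acid at the end of the chain would give a step beyond the scatter in this assay. As far as these compounds go, it is equally open whether a much longer chain, or a phenyl ring carried on this chain, would leave the number as undisturbed as the double bond does on the shared core.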